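A few compounds are considered here, and "the series" means these few. Any claim that something is new, unique, unknown or untested is made for them only; others in the source may bear on it.

Going by the values given here, of the two compounds measured so far in an ADME assay on Vero cells (Chlorocebus sabaeus) for cytotoxicity, read by sulforhodamine B assay, with a stated time of 3 days (a lower number here means that less compound is tolerated, a higher number that more compound is tolerated), compound 1 `COc1ccc(NC(=O)C2=C(C)NC(=O)NC2c2ccco2)cc1` has the higher number at 210 ug/mL. Compound 2 `COc1ccc(NC(=O)C2=C(C)NC(=S)NC2c2cccc([N+](=O)[O-])c2)cc1` gives 80 ug/mL, a gap beyond the usual scatter. Compound 3 `COc1ccc(NC(=O)C2=C(C)NC(=O)NC2c2ccc(O)c(OC)c2)cc1` has not yet been measured. It differs from compound 1 in one place: 4-hydroxy-3-methoxyphenyl in place of furan-2-yl on a saturated ring carbon. In words, it carries 4-hydroxy-3-methoxyphenyl in place of furan-2-yl on a saturated ring carbon. Among the compounds with values here, no measured pair of compounds differs in only one place, so the data do not show what such a change does in this assay. The starting point is therefore compound 1 at 210 ug/mL, with no change beyond the scatter expected. The expected step is small, a 1.4-fold lower number from compound 1 to compound 3 (0.15 log units; within the scatter). For compound 3, the estimated value is 150 ug/mL, with an expected range from 60 ug/mL to 350 ug/mL.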

Compound 3, half-maximal cytotoxic concentration: 8 ug/mL
Estimate against measurement, compound 3: 19-fold (1.27 log units) above, and the stated range ends above it.
By their numbers in this assay, from the lowest: compound 3; then compound 2; then compound 1.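

In this assay the group on this saturated ring carbon proves to matter a great deal: 4-hydroxy-3-methoxyphenyl in place of furan-2-yl gives a 26-fold lower number from compound 1 to compound 3 (1.42 log units; beyond the scatter) and a step of that size means the cells tolerate far less of the compound. Going by these compounds alone, this is the first pair that differs in only one place, so it shows that the shared core does not set the number by itself and that a change at this carbon alone can move it well beyond the scatter. No available measurement explains the step.

The change swaps the ring type and brings in both a hydroxy and a methoxy group, so these compounds cannot show which part carries the step. Going by these compounds, whether a plain phenyl group on this carbon would stay close to compound 1 or fall towards compound 3 remains open.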